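The source may hold more compounds than are shown below. What is called first, only, known or untested is meant among the compounds shown, and "the series" means these compounds.

Series built on the shared core of compound 1 `Cc1cc(Sc2ccccc2Cl)c(S(C)(=O)=O)cc1C(=O)N=C(N)N`; in a functional assay for inhibition of sodium/hydrogen exchanger (Oryctolagus cuniculus) (a lower number here means a stronger inhibitor, a higher number a weaker inhibitor), compound 1 gives 14 nM. Compound 2 `COc1cc(C)c(C(=O)N=C(N)N)cc1S(C)(=O)=O` gives 16 nM, and compound 3 `Cc1cc(Oc2ccc(Cl)cc2)c(S(C)(=O)=O)cc1C(=O)N=C(N)N` gives 13 nM. On these three numbers compound 3 holds the lowest value, but its steps to the other two fall within the scatter, so no order among the three can be read: a 1.1-fold higher number from compound 1 to compound 2 (0.06 log units; within the scatter), a 1.1-fold lower number from compound 1 to compound 3 (0.03 log units; within the scatter), a 1.2-fold lower number from compound 2 to compound 3 (0.09 log units; within the scatter).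

Compound 4 `Cc1ccc(S(C)(=O)=O)cc1C(=O)N=C(N)N` is not yet measured. The change from compound 3 is hydrogen in place of 4-chlorophenoxy on an aromatic carbon. The step that bears most directly on it is a 1.2-fold lower number from compound 2 to compound 3 (0.09 log units; within the scatter), which exchanged one group for another on the oxygen at this aromatic carbon and left the number within the scatter; a 1.1-fold higher number from compound 1 to compound 2 (0.06 log units; within the scatter) and a 1.1-fold lower number from compound 1 to compound 3 (0.03 log units; within the scatter) likewise show three different groups at this aromatic carbon giving the same number within the scatter. None of these steps removes the group altogether, so there is no direct guide to a bare hydrogen there. For compound 4 the expected step is a 2.3-fold higher number from compound 3 to compound 4 (0.36 log units; beyond the scatter), leaning toward a higher number but with a wide range. Compound 4 is therefore estimated at 30 nM, within a range of 10 nM to 100 nM.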

Compound 4, half-maximal inhibitory concentration: 150 nM
Estimate against measurement, compound 4: 5.0-fold (0.70 log units) below; the measured number lies above the stated range.
By their numbers in this assay, from the lowest: compounds 3, 1 and 2 (each within the scatter of the next); then compound 4.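

In this assay, this aromatic carbon, ortho to a methylsulfonyl group, does not tolerate losing its substituent: hydrogen in place of 4-chlorophenoxy gives the large step (a 12-fold higher number from compound 3 to compound 4 (1.06 log units; beyond the scatter)), hydrogen in place of methoxy gives a modest one (a 9.4-fold higher number from compound 2 to compound 4 (0.97 log units; beyond the scatter)), and hydrogen in place of (2-chlorophenyl)sulfanyl gives another large one (an 11-fold higher number from compound 1 to compound 4 (1.03 log units; beyond the scatter)). All three steps lie beyond the scatter, whereas compounds 1, 2 and 3 stay within the scatter of one another, so among the listed compounds the clear separation is between a bare hydrogen and any of the three groups, with no compound going against this. The data offer no measurement that accounts for this separation.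

From the compounds shown here alone, compounds 1, 2 and 3 all carry their group through an oxygen or a sulfur, so it remains open whether a group attached directly through nitrogen or carbon, such as an amine or a carboxylic acid, would stay with compounds 1, 2 and 3 or sit nearer compound 4. Also open, going by these compounds, is whether a lone fluorine or chlorine on this carbon would be enough to keep the number with compounds 1, 2 and 3.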